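A few compounds are considered here, and "the series" means these few. Any claim that something is new, unique, unknown or untested is made for them only; others in the source may bear on it.

Of the compounds shown here, three sharing one core have been measured in a functional assay on M14 cells (Homo sapiens) for inhibition, read by sulforhodamine B assay, with a stated time of 48 h, tested at 0.01 uM; a lower number here means a stronger effect, a higher number a weaker effect of the compound at the concentration tested. Compound 1 `O=C(Nc1cccc(-n2cc(-c3ccncc3)c(-c3cc(O)cc(Cl)c3)n2)c1)Nc1ccc(Cl)c(C(F)(F)F)c1` gives 97% in this assay. Compound 2 `O=C(Nc1cccc(-n2cc(-c3ccncc3)c(-c3cc(O)cc(Cl)c3)n2)c1)Nc1ccc(Cl)c(Cl)c1`, which carries chloro in place of trifluoromethyl on an aromatic carbon, gives 99%; the step of a number 2 percentage points higher from compound 1 to compound 2 (within the scatter) stays within the scatter. Compound 3 `COc1cc(Cl)cc(-c2nn(-c3cccc(NC(=O)Nc4ccc(Cl)c(C(F)(F)F)c4)c3)cc2-c2ccncc2)c1` is the methyl ether of compound 1; in this assay compound 3 gives 97%, and the step of no change at the digits printed from compound 1 to compound 3 (within the scatter) is likewise within the scatter. Compound 3 thus stands level with compound 1 at the digits printed, and all three numbers lie within the usual scatter of one another, so no order can be read among them.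

Compound 4 `COc1cc(Cl)cc(-c2nn(-c3cccc(NC(=O)Nc4ccc(Cl)c(Cl)c4)c3)cc2-c2ccncc2)c1` has not yet been measured. It differs from compound 3 as follows: chloro in place of trifluoromethyl on an aromatic carbon. This is the same change already seen between compound 1 and compound 2, where a number 2 percentage points higher from compound 1 to compound 2 (within the scatter) was within the scatter, and compound 4 carries it on the methyl ether of compound 3. Among the compounds with values here, nothing among the measured compounds suggests that this exchange alters the read-out in this assay. The expected step is therefore a number 1 percentage points higher from compound 3 to compound 4 (within the scatter), which is no change beyond the scatter. Compound 4 is accordingly estimated to give 98% in this assay, within a range from 91% to 105%.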

Compound 4, a percentage reported as activity, at one concentration (the size of the read-out at that concentration, not a potency): 97%
For compound 4 the middle estimate is 1 percentage points above the measured one; the measured number falls inside the stated range.
By their numbers in this assay, from the lowest: compounds 1, 3, 4 and 2 (each within the scatter of the next).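

Chloro in place of trifluoromethyl, on the aromatic carbon ortho to a chloro group, has now been read on a second core in this assay, the methyl ether, where it gives no change at the digits printed from compound 3 to compound 4 (within the scatter), and the two readings of this change agree: the same change on two cores in this assay, a number 2 percentage points higher (within the scatter) from compound 1 to compound 2 and no change at the digits printed (within the scatter) from compound 3 to compound 4, 2 percentage points apart, within the scatter of two such steps. Methyl in place of hydrogen on the oxygen has likewise been read a second time, now with the 3,4-dichlorophenyl group present, where it gives a number 2 percentage points lower from compound 2 to compound 4 (within the scatter), and these two readings also agree: the same change on two cores in this assay, no change at the digits printed (within the scatter) from compound 1 to compound 3 and a number 2 percentage points lower (within the scatter) from compound 2 to compound 4, 2 percentage points apart, within the scatter of two such steps. Across the four compounds, neither change moves the number beyond the scatter on either core, so the 3,4-dichlorophenyl and 4-chloro-3-(trifluoromethyl)phenyl groups cannot be told apart here, with either the hydroxy group or its methyl ether on the other side of the molecule.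

The compounds shown leave open whether a different group at this position, such as an amine, a carboxylic acid or a longer alkyl chain, would shift the number in this assay. With a single concentration as the only read-out, they also leave open whether these four compounds differ in potency.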